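This account rests on a few compounds, and the source may have more. Where it says the series, first, only, none or still open, it means among the compounds named here.

Compound 3 `COc1ccc(-c2c(C)nc3c(N4CC[C@@H](NS(=O)(=O)c5ccc(C)cc5)C4)cc(C)nn23)cc1OC` stands at the top of the numbers shown: in an ADME assay on microsomes from liver (Homo sapiens) for metabolic stability, read by LC-MS, with NADPH named in the record, with a stated time of 60 min, tested at 1 uM, in the absence of a further agent (a lower number here means that less of the compound is left, a higher number that more of the compound is left), compound 3 gives > 95%, which is a limit of the assay rather than a number. Compound 1 `COc1ccc(-c2c(C)nc3c(N4CC[C@@H](NC(=O)c5ccccc5)C4)cc(C)nn23)cc1OC` gives > 95% in this assay, likewise a limit. Compound 2 `COc1ccc(-c2c(C)nc3c(N4CC[C@@H](NC(=O)Nc5ccccc5)C4)cc(C)nn23)cc1OC` gives > 95% in this assay, also a limit. The three measured steps among them, a step that the two limits leave unreadable from compound 1 to compound 2, a step that the two limits leave unreadable from compound 1 to compound 3 and a step that the two limits leave unreadable from compound 2 to compound 3, cannot be read in size or direction because of the limit of > 95% in this assay, at which 3 of the 3 values shown sit.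

Compound 4 `COc1ccc(-c2c(C)nc3c(N4CC[C@@H](OC(C)=O)C4)cc(C)nn23)cc1OC` differs from compound 3 at the saturated ring carbon: acetoxy in place of ((4-methylphenyl)sulfonyl)amino on a saturated ring carbon. For the measured compounds named here, no measured step touches an acetoxy group, and the three known exchanges, all of which replace one group by another on the amine nitrogen or the carbonyl carbon, yielded no readable step at all. Going by the values given here, there is therefore no measured step that bears on this change in a way that gives a size or a direction; the only footing is that all three measured compounds sit at the limit. Compound 4 is expected to remain fairly high but to carry a real chance of falling below the limit, so its estimate in this assay is 80%, within 55% to 97%. The step from compound 3 to compound 4 is thus expected to be a number at least 15 percentage points lower from compound 3 to compound 4 (beyond the scatter).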

Compound 4, percent of the compound remaining: > 95%
Compound 4: no number, only a limit; the forecaster's own chance of this, stated with the estimate: 35%; middle value at least 15 percentage points from the limit.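

The steps joining compound 4 to compound 1, compound 2 and compound 3 in this assay cannot be read in size or direction, because each of these compounds gives only a limit of the assay: the limit of > 95% in this assay, at which 4 of the 4 values shown sit. The compounds shown leave open whether these four differ at all in this assay, and which exchange, if any, would give a readable step.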